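The compounds below may be only part of what the source reports. "The series", "measured", "known", "first", "only" and "open" are said of these compounds alone.

Measured so far in an assay on isolated protein for inhibition of Apoptosis regulator Bcl-2 (Homo sapiens), read by fluorescence polarization; on this read-out higher numbers stand for weaker inhibition and lower numbers for stronger inhibition:

Compound 1 `Cc1cccc(N2C(=O)/C(=C/c3ccc(OCc4ccc(C(=O)O)cc4)cc3)SC2=S)c1` — in this assay compound 1 gives > 10000 nM, a limit of the assay and not a number.
Compound 2 `COc1ccc(N2C(=O)/C(=C/c3ccc(OCc4ccc(C(=O)O)cc4)cc3)SC2=S)cc1` — in this assay compound 2 gives > 10000 nM, again a limit.
Compound 3 `O=C(O)c1ccc(COc2ccc(/C=C3\SC(=S)N(c4cccc(C(F)(F)F)c4)C3=O)cc2)cc1` — in this assay compound 3 gives > 10000 nM, also a limit.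

Compound 3 therefore stands where every measured member of the series stands: at the limit of > 10000 nM in this assay, at which 3 of the 3 values shown sit. The three steps among the measured compounds all exchange the aryl group on the ring nitrogen of the shared core, and none of them can be sized: a step that the two limits leave unreadable from compound 1 to compound 2, a step that the two limits leave unreadable from compound 1 to compound 3 and a step that the two limits leave unreadable from compound 2 to compound 3 are each left unreadable by the two limits on either side.

Compound 4 `O=C(O)c1ccc(COc2ccc(/C=C3\SC(=S)N(c4c(F)cccc4F)C3=O)cc2)cc1` is the next point on the same line of variation. The change from compound 3 is 2,6-difluorophenyl in place of 3-(trifluoromethyl)phenyl on an amide-type nitrogen in a ring. For the measured compounds named here, the steps that bear on it are exactly the three unreadable ones, so they give no direction and no size, only the observation that three different aryl groups on this nitrogen have all stayed at the limit. No step beyond the scatter is expected in this assay; the expected step that the limit leaves unreadable from compound 3 to compound 4 is essentially flat. Compound 4 is estimated at 20000 nM, within a range from 8000 nM to 60000 nM, with a high chance that the assay again reports only a limit.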

Compound 4, inhibition constant: > 10000 nM
Compound 4 ended at the assay's limit (the forecaster's own chance of this, stated with the estimate: 85%); the middle value does not contradict the limit.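

The steps from compound 1, compound 2 and compound 3 to compound 4 cannot be read, as all four results are limits of the assay and not numbers: the limit of > 10000 nM in this assay, at which 4 of the 4 values shown sit.

The compounds shown leave open whether any aryl group on the ring nitrogen of the shared core gives a measurable inhibition constant in this assay at all.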